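Cytotoxicity of a dichlorophenyl amide on hamster kidney cells

This account rests on a few compounds, and the source may have more. Where it says the series, first, only, none or still open, it means among the compounds named here.

Compound 3 `O=C(CCSc1nnc(-c2ccncc2)s1)Nc1ccccc1` was tested in an ADME assay on BHK-21 cells (Mesocricetus auratus) for cytotoxicity, with a stated time of 3 days; a lower number here means that less compound is tolerated, a higher number that more compound is tolerated. In this assay compound 3 gives only a limit, > 50000 nM. The two related compounds stand no differently. In this assay compound 1 `CC(Sc1nnc(-c2ccncc2)s1)C(=O)Nc1ccc(Cl)cc1Cl` reaches a limit, > 50000 nM. In this assay compound 2 `CC(Sc1nnc(-c2ccncc2)s1)C(=O)NCc1ccccc1Cl` also sits at a limit, > 50000 nM. For the measured compounds named here, the one step between measured compounds, a step that the two limits leave unreadable from compound 1 to compound 2, is therefore unreadable. Compound 4 `O=C(CCSc1nnc(-c2ccncc2)s1)Nc1ccc(Cl)cc1Cl` differs from compound 3 by 2,4-dichlorophenyl in place of phenyl on an amide-type nitrogen. Going by the values given here, no measured step can size this change; all that is known is the limit of > 50000 nM in this assay, at which 3 of the 3 values shown sit. No movement beyond the scatter is expected, and a limit again seems the most likely outcome. Compound 4 is estimated at 80000 nM, with a range from 40000 nM to 300000 nM. This estimate corresponds to a step that the limit leaves unreadable from compound 3 to compound 4.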

Compound 4, half-maximal cytotoxic concentration: > 50000 nM
Compound 4 gave a limit, no number; the forecaster's own chance of this, stated with the estimate: 85%; the middle value is on the limit's open side.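

For the compounds shown here, compound 3 and compound 4 both give only a limit in this assay, and no step between them can be read. The compounds shown leave open at what concentration any of them becomes cytotoxic: the limit of > 50000 nM in this assay, at which 4 of the 4 values shown sit.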